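A Nitro-Fluoro Swap on a Weak Growth Inhibitor

The source may report more compounds than this note shows. Statements on the series, on what has been measured and on what is new or still open speak of the compounds shown alone.

Compound 1 (`O=C(O)c1ccc(C(=O)/C(=C\c2ccc(Br)cc2)SCc2ccc(F)cc2)cc1`) gives > 100000 nM (a limit of the assay, not a number)
Compound 2 (`O=C(/C(=C\c1ccccc1OCc1ccccc1)S(=O)(=O)Cc1ccc(Cl)cc1)c1ccc(Br)cc1`) gives 10000 nM (a number)

Among the compounds with values here, both results come from a functional assay on DU-145 cells (Homo sapiens) for inhibition, read by trypan blue exclusion, with a stated time of 96 h (on this read-out higher numbers stand for weaker inhibition of growth and lower numbers for stronger inhibition of growth), and no measured step links them. Compound 1 has no number of its own, and its reading is only a limit (the limit of > 100000 nM in this assay, at which 1 of the 2 values shown sits). Compound 2 differs from compound 1 in more than one place and offers no single-change comparison.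

Compound 3 (`O=C(O)c1ccc(C(=O)/C(=C\c2ccc(F)c([N+](=O)[O-])c2)SCc2ccc(F)cc2)cc1`) keeps the core of compound 1 and carries 4-fluoro-3-nitrophenyl in place of 4-bromophenyl on a double-bonded chain carbon bound to a double-bonded chain carbon. Nothing measured shows what this exchange does in this assay (the expectation is therefore cautious). Only a small move toward stronger inhibition of growth is expected, and compound 3 may well also end at a limit. The estimate amounts to an at least 1.4-fold lower number from compound 1 to compound 3 (0.15 log units; that floor lies within the scatter) (a small step at best). For compound 3 the estimated value is 70000 nM (expected range 15000 nM to 200000 nM).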

Compound 3, concentration for 50% growth inhibition: 1000 nM
Compound 3: the middle estimate sits 70-fold (1.85 log units) above what was measured; the measured number lies below the stated range.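

Within the data shown here, exchanging 4-bromophenyl for 4-fluoro-3-nitrophenyl on a double-bonded chain carbon bound to a double-bonded chain carbon gives, in this assay, an at least 100-fold lower number from compound 1 to compound 3 (2.00 log units; beyond the scatter), so this position can carry a change that moves growth inhibition well past the usual scatter, something the earlier compounds could not show. Compound 3, at 1000 nM, gives a real number on the shared core, so any later change at this position can be read against a measured value. Compound 1 is read only as a limit, which makes this step a floor and not a full size: the limit of > 100000 nM in this assay, at which 1 of the 3 values shown sits.

The exchange brings in the fluorine and the nitro group together, and the compounds shown do not tell which of the two carries the gain, or whether a ring holding only one of them would do as well. They also leave open whether a nitrile or an amine in the place of the nitro group would keep the growth inhibition seen with compound 3.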